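This account rests on a few compounds, and the source may have more. Where it says the series, first, only, none or still open, it means among the compounds named here.

Measured so far in a functional assay on HL-60 cells (Homo sapiens) for inhibition, read by MTT assay, with a stated time of 48 h, tested at 10 uM; a lower number here means less inhibition of growth, a higher number more inhibition of growth at the concentration tested:

- compound 1 `Cc1cc(=O)c2c(O)cc(OCc3ccc([N+](=O)[O-])cc3)c([C@H]3CCN(C)C[C@H]3O)c2o1` gives 14%
- compound 2 `CCOC(=O)N1CCN(Cc2c(O)c([C@H]3CCN(C)C[C@H]3O)c3oc(C)cc(=O)c3c2O)CC1` gives 16%
- compound 3 `Cc1oc2c([C@H]3CCN(C)C[C@H]3O)c(O)cc(O)c2c(=O)c1C(O)c1c(Cl)cccc1Cl` gives 14%

Compound 3 at 14% stands level with compound 1 at 14% on these numbers, and compound 2 at 16% lies within the scatter of both.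

Compound 4 `CCOc1ccc(Br)c(C(O)c2c(C)oc3c([C@H]4CCN(C)C[C@H]4O)c(O)cc(O)c3c2=O)c1` is still unmeasured. It has 2-bromo-5-ethoxyphenyl in place of 2,6-dichlorophenyl on a saturated chain carbon bound to an aromatic carbon and an oxygen on a saturated carbon and is otherwise the same as compound 3.

Among the measured compounds shown here, no two measured compounds differ in one place only, so no measured step isolates this change. The three compounds carry quite different groups on the shared core, yet they all remain within the scatter of one another. In this assay a step no larger than the scatter is therefore expected, with only a slight lean upward. The estimated move is a number 4 percentage points higher from compound 3 to compound 4 (within the scatter). This expectation rests on compound 3 at 14% as the closest neighbour. The range is kept wide on the upper side, since the new group has not been tested in this series. For compound 4 the expected value is 18%, within an estimated range of 6% to 38%.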

Compound 4, percent growth inhibition at one concentration: 2%
Compound 4: middle estimate off by 16 percentage points, on the high side; measured number below the stated range.
By their numbers in this assay, from the lowest: compound 4; then compounds 1, 3 and 2 (each within the scatter of the next).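

In this assay, among the compounds shown here, the 2-bromo-5-ethoxyphenyl group in place of 2,6-dichlorophenyl, on a saturated chain carbon bound to an aromatic carbon and an oxygen on a saturated carbon, gives a number 12 percentage points lower from compound 3 to compound 4 (beyond the scatter), the first single-place step and one that leaves the scatter. This position is therefore not indifferent to what its aromatic ring carries, even though the ring itself remains a six-membered aromatic ring of carbon only and the change goes with less inhibition of growth at the concentration tested. For the compounds shown here, nothing measured so far speaks to why the number falls.

Bromine and ethoxy enter together while both chlorines leave, so it remains open whether a phenyl carrying only bromine or only ethoxy would read like compound 3 or like compound 4. Also open, from the compounds shown here alone, is what an amine or a carboxylic acid on that ring would do, and whether a longer alkoxy chain in place of ethoxy would move the number further in this assay.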